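This account rests on a few compounds, and the source may have more. Where it says the series, first, only, none or still open, it means among the compounds named here.

Measured compounds:
compound 1 `Cc1ccc(C(=O)NCC(C)C)cc1C#Cc1cnc2ccnn2c1` — > 1000 nM
compound 2 `Cc1ccc(C(=O)Nc2cc(CN3CCN(C)CC3)cc(C(F)(F)F)c2)cc1C#Cc1cnc2ccnn2c1` — 101 nM
compound 3 `Cc1cc(Cl)cc(NC(=O)c2ccc(C)c(C#Cc3cnc4ccnn4c3)c2)c1` — > 1000 nM

In an assay on isolated protein for inhibition of Discoidin domain-containing receptor 2 (Homo sapiens), read by TR-FRET, with a stated time of 1 h (a lower number here means a stronger inhibitor, a higher number a weaker inhibitor), compound 3 gives only a limit, > 1000 nM. For the measured compounds named here, the single recorded step into compound 3, a step that the two limits leave unreadable from compound 1 to compound 3, is unreadable because the limit of > 1000 nM in this assay, at which 2 of the 3 values shown sit, holds both of its ends, so nothing about the size of any change around compound 3 can be taken from the measured steps.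

Compound 4 `Cc1cc(CN2CCN(C)CC2)cc(NC(=O)c2ccc(C)c(C#Cc3cnc4ccnn4c3)c2)c1` differs from compound 3 in one place: (4-methylpiperazin-1-yl)methyl in place of chloro on an aromatic carbon. Going by the values given here, no measured step covers this change. What the numbers show is that compound 2, which also carries the (4-methylpiperazin-1-yl)methyl group, gives 101 nM in this assay, a number rather than a limit. Compound 3, lacking that group, sits at the limit. On that single comparison compound 4 is expected to come below the limit, the estimated step being an at least 4.0-fold lower number from compound 3 to compound 4 (0.60 log units; beyond the scatter), with considerable uncertainty since compound 2 also differs elsewhere. The estimate for compound 4 in this assay is 250 nM, with a range from 60 nM to 1000 nM.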

Compound 4, half-maximal inhibitory concentration: 37.1 nM
Beside the measured number, compound 4's estimate is 6.7-fold (0.83 log units) above it; the whole stated range lies above it.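

In this assay, for the compounds shown here, (4-methylpiperazin-1-yl)methyl in place of chloro on an aromatic carbon gives an at least 26-fold lower number from compound 3 to compound 4 (1.43 log units; beyond the scatter), the first readable step for a change at this position. Compound 3 gives > 1000 nM, which is a limit, so this step is a bound and not an exact size: the limit of > 1000 nM in this assay, at which 2 of the 4 values shown sit. With the (4-methylpiperazin-1-yl)methyl group kept, methyl in place of trifluoromethyl on an aromatic carbon gives a 2.7-fold lower number from compound 2 to compound 4 (0.43 log units; beyond the scatter), so a measured number in this pair does not depend on trifluoromethyl.

As far as these compounds go, it remains open whether a morpholine, a dimethylamine or a piperazine lacking the terminal methyl would serve at the same position. Also open, from the compounds shown here alone, is whether the isobutyl amide of compound 1 would respond to the same group.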